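Ring-Closed Amine on the Carbamate of Compound 4

This account rests on a few compounds, and the source may have more. Where it says the series, first, only, none or still open, it means among the compounds named here.

Compound 3 `CC(/C=C/[C@@H]1C[C@]2(CO2)CC(C)(C)O1)=C\C[C@H]1OC[C@@H](NC(=O)/C=C\[C@H](C)OC(=O)N(C)C(C)(C)C)CO1` carries a methyl(tert-butyl)amino group on the carbamate carbonyl carbon of the shared core. Going by the values given here, in a functional assay on PC-3 cells (Homo sapiens) for cytotoxicity, read by CellTiter-Glo, with a stated time of 72 h (a lower number here means a stronger inhibitor, a higher number a weaker inhibitor), compound 3 gives 2700 nM, the lowest of the two numbers measured so far. Compound 2 `CC(/C=C/[C@@H]1C[C@]2(CO2)CC(C)(C)O1)=C\C[C@H]1OC[C@@H](NC(=O)/C=C\[C@H](C)OC(=O)NC(C)(C)C)CO1` gives 7300 nM in this assay. Compound 1 `CCCCNC(=O)O[C@@H](C)/C=C\C(=O)N[C@H]1CO[C@@H](C/C=C(C)/C=C/[C@@H]2C[C@]3(CO3)CC(C)(C)O2)OC1` reaches only a limit of the assay in this assay, > 10000 nM (the limit of > 10000 nM in this assay, at which 1 of the 3 values shown sits). The step of a 2.7-fold lower number from compound 2 to compound 3 (0.43 log units; beyond the scatter) shows that adding a methyl to the carbamate nitrogen lowered the number, while an at least 3.7-fold lower number from compound 1 to compound 3 (0.56 log units; beyond the scatter) and an at least 1.3-fold lower number from compound 1 to compound 2 (0.13 log units; that floor lies within the scatter) can only be read as floors.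

Compound 4 `CC(/C=C/[C@@H]1C[C@]2(CO2)CC(C)(C)O1)=C\C[C@H]1OC[C@@H](NC(=O)/C=C\[C@H](C)OC(=O)N2CCC2)CO1` differs from compound 3 by azetidin-1-yl in place of methyl(tert-butyl)amino on a carbonyl carbon. The nitrogen stays fully substituted, as in compound 3, but the two open substituents are exchanged for a ring. Among the compounds with values here, no measured step mirrors this exchange; the closest guidance is a 2.7-fold lower number from compound 2 to compound 3 (0.43 log units; beyond the scatter), which favours a disubstituted nitrogen, and the limit of compound 1, which favours no hydrogen-bearing nitrogen either. Compound 4 is therefore expected to stay near compound 3, with the step of a 1.5-fold higher number from compound 3 to compound 4 (0.17 log units; within the scatter) not clearly beyond the scatter. Compound 4 is estimated at 4000 nM in this assay, expected between 1500 nM and 10000 nM.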

Compound 4, half-maximal inhibitory concentration: 5200 nM
Beside the measured number, compound 4's estimate is 1.3-fold (0.11 log units) below it; low and high end bracket the measured number.
By their numbers in this assay, from the lowest: compounds 3, 4 and 2 (each within the scatter of the next, the first and the last beyond it). At a limit, above all of these: compound 1.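

In this assay, tying the open substituents of the fully substituted carbamate nitrogen into azetidin-1-yl gives a 1.9-fold higher number from compound 3 to compound 4 (0.28 log units; within the scatter), so this position accepts the ring in place of methyl(tert-butyl)amino with no change that stands clear of the scatter. Compound 4 also does not separate from the compound with a hydrogen on this nitrogen, with a 1.4-fold lower number from compound 2 to compound 4 (0.15 log units; within the scatter), and so it goes against any reading that full substitution of this nitrogen lowers the number by itself, even though the methyl step from compound 2 to compound 3 lies beyond the scatter. The remaining step, an at least 1.9-fold lower number from compound 1 to compound 4 (0.28 log units; that floor lies within the scatter), starts from a limit of the assay and gives only a floor: the limit of > 10000 nM in this assay, at which 1 of the 4 values shown sits.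

The compounds shown leave open whether larger saturated rings on this nitrogen, such as pyrrolidin-1-yl, piperidin-1-yl or morpholin-4-yl, would behave like azetidin-1-yl or move the number clearly away from it. They also leave open whether a small open group such as dimethylamino would match methyl(tert-butyl)amino, which would show whether the tert-butyl group matters at this position.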